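A few compounds are considered here, and "the series" means these few. Any claim that something is new, unique, unknown or untested is made for them only; others in the source may bear on it.

Compound 1 (`FC(F)(F)c1cccc(-c2nc3cnc(Nc4cccnn4)cc3[nH]2)c1`) gives 69% in an ADME assay on microsomes from liver (Rattus norvegicus) for metabolic stability, read by LC-MS, with a stated time of 30 min, tested at 0.1 uM; a higher number here means that more of the compound is left, a lower number that less of the compound is left
Compound 2 (`FC(F)(F)c1ccc(Nc2cc3[nH]c(-c4cccc(C(F)(F)F)c4)nc3cn2)nc1`) gives 89% in this assay

Of these two numbers, compound 2 holds the highest, with 89% as its reading. Going by the values given here, the only measured step (a number 20 percentage points higher from compound 1 to compound 2 (beyond the scatter)) is modest, lies beyond the scatter and concerns the group on a nitrogen. Compound 3 (`FC(F)(F)c1ccc(Nc2cc3[nH]c(C4CC4)nc3cn2)nc1`) departs from compound 2 at another place. It carries cyclopropyl in place of 3-(trifluoromethyl)phenyl on an aromatic carbon of a five-membered aromatic ring, between two ring nitrogen atoms (cyclopropyl in place of 3-(trifluoromethyl)phenyl on an aromatic carbon). Among the compounds with values here, no measured step touches this place, so the one step available serves only as a rough gauge of size. With compound 2 at 89% on this read-out there is little room upward, so a modest drop, or none beyond the scatter, is what is expected. The expected change is estimated as a number 9 percentage points lower from compound 2 to compound 3 (within the scatter). Compound 3 is estimated at 80% in a range from 60% to 96% and awaits measurement.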

Compound 3, percent of the compound remaining: 96%
Compound 3: the middle estimate sits 16 percentage points below what was measured; low and high end bracket the measured number.
By their numbers in this assay, from the lowest: compound 1; then compounds 2 and 3 (each within the scatter of the next).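

In this assay, going by these compounds alone, replacing 3-(trifluoromethyl)phenyl with cyclopropyl on the aromatic carbon between two ring nitrogen atoms gives a number 7 percentage points higher from compound 2 to compound 3 (within the scatter), and this is the first reading of any change at this position. It shows that, with 5-(trifluoromethyl)pyridin-2-yl on the nitrogen, a group of 10 heavy atoms with a six-membered aromatic ring can give way to one of 3 heavy atoms with a three-membered non-aromatic ring, and the two readings cannot be told apart. Nothing measured here accounts for this outcome, and no reason for it can be offered.

The compounds shown leave open how this position would read with a different kind of group on that carbon, such as an amine, a carboxylic acid, a longer alkyl chain or a bare hydrogen. Within the data shown here, they also leave open whether cyclopropyl would give a similar reading with pyridazin-3-yl on the nitrogen, since the single exchange at this position was seen only with 5-(trifluoromethyl)pyridin-2-yl in place.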